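A few compounds are considered here, and "the series" means these few. Any claim that something is new, unique, unknown or untested is made for them only; others in the source may bear on it.

In an assay on THP-1 cells for antagonist activity at P2X purinoceptor 7 (Homo sapiens), read by ELISA, with a stated time of 30 min (on this read-out higher numbers stand for weaker inhibition and lower numbers for stronger inhibition), compound 1 `N#Cc1cccc(S(=O)(=O)Oc2ccc(-c3cncn3C3CCN(C(=O)c4ccc(Cl)c(C(F)(F)F)c4)CC3)cc2)c1` gives 4.28 nM, and compound 2 `O=C(NC1CC1)c1cccc(S(=O)(=O)Oc2ccc(-c3cncn3C3CCN(C(=O)c4ccc(Cl)c(C(F)(F)F)c4)CC3)cc2)c1` gives 58 nM. Among the compounds with values here, the one change between them, a 14-fold higher number from compound 1 to compound 2 (1.13 log units; beyond the scatter), is the only measured step here, and it sits on the aryl group of the sulfonate ester. Compound 3 `CS(=O)(=O)c1ccc(C(=O)N2CCC(n3cncc3-c3ccc(OS(=O)(=O)c4cccc5cnccc45)cc3)CC2)cc1` gives 0.32 nM, the lowest number of the three; it differs from compound 1 and compound 2 in several places at once, so no single step can be read from those gaps.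

Compound 4 `CC(C)(O)c1ccc(C(=O)N2CCC(n3cncc3-c3ccc(OS(=O)(=O)c4cccc5cnccc45)cc3)CC2)cc1` is the untested compound. It differs from compound 3 in one place: 1-hydroxy-1-methylethyl in place of methylsulfonyl on an aromatic carbon. Within the data shown here, no measured step touches this part of the molecule, so the only guide is the size of the one known step, which is large, and the fact that the group that leaves and the group that enters are of similar size. On that basis the expected step from compound 3 to compound 4 is modest, a 1.9-fold higher number from compound 3 to compound 4 (0.27 log units; within the scatter), with no firm direction. Compound 4 is therefore estimated at 0.6 nM, within a range from 0.15 nM to 3 nM.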

Compound 4, half-maximal inhibitory concentration: 4.7 nM
Estimate against measurement, compound 4: 7.8-fold (0.89 log units) below, outside the stated range (above it).
By their numbers in this assay, from the lowest: compound 3; then compounds 1 and 4 (each within the scatter of the next); then compound 2.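

Replacing methylsulfonyl with 1-hydroxy-1-methylethyl, on an aromatic carbon para to a large group, gives a 15-fold higher number from compound 3 to compound 4 (1.17 log units; beyond the scatter) in this assay, so the substituent on this benzoyl ring matters as well as the aryl group of the sulfonate ester, the only site varied by the earlier step. Both groups have 4 heavy atoms, so matching that count did not keep the number low, although the two groups differ in their double bonds, hydrogen-bond donors and hydrogen-bond acceptors. No measurement here shows which of those differences accounts for the step.

The compounds shown leave open how an amine, a carboxylic acid or a plain hydrogen would fare at this place. They also leave open whether this change would give a step of similar size with a different aryl group on the sulfonate ester.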